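A few compounds are considered here, and "the series" means these few. Any claim that something is new, unique, unknown or untested is made for them only; others in the source may bear on it.

Measured so far:
- compound 1, `NCc1ccc(C(=O)OCc2ccccc2)cc1`, in an assay on isolated protein for inhibition of serine protease 1 (Homo sapiens) (on this read-out higher numbers stand for weaker inhibition and lower numbers for stronger inhibition), gives 30000000 nM
- compound 2, `CCCCOC(=O)c1ccc(CN)cc1`, in this assay gives 910000000 nM
- compound 3, `CCCCCCOC(=O)c1ccc(CN)cc1`, in this assay gives 300000000 nM

Compound 3 stands second highest of the three numbers: a 10-fold higher number from compound 1 to compound 3 (1.00 log units; beyond the scatter), while a 3.0-fold lower number from compound 2 to compound 3 (0.48 log units; beyond the scatter). Compound 4 is `CCCCCOC(=O)c1ccc(CN)cc1`; it differs from compound 3 by hydrogen in place of methyl on a saturated chain carbon, five bonds along the chain from an oxygen next to a carbonyl group, which sits between the butyl chain of compound 2 and the hexyl chain of compound 3. Among the measured compounds shown here, the only step bearing on it is the chain lengthening from compound 2 to compound 3, modest in size; shortening by one carbon is expected to give back part of that, so a modest higher number is estimated, a 1.7-fold higher number from compound 3 to compound 4 (0.22 log units; within the scatter). Compound 4 is therefore expected at 500000000 nM, within 250000000 nM to 1000000000 nM.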

Compound 4, inhibition constant: 700000000 nM
The estimate for compound 4 lay 1.4-fold (0.15 log units) below the measured number, within the range that was stated.
By their numbers in this assay, from the lowest: compound 1; then compound 3; then compounds 4 and 2 (each within the scatter of the next).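

In this assay the shortening of the chain gives a 2.3-fold higher number from compound 3 to compound 4 (0.37 log units; beyond the scatter) and so separates the hexyl chain from the pentyl chain, while a 1.3-fold lower number from compound 2 to compound 4 (0.11 log units; within the scatter) leaves the butyl and pentyl chains unresolved, so the three chains show no even trend with length. The phenyl compound also stays apart from the pentyl chain, with a 23-fold higher number from compound 1 to compound 4 (1.37 log units; beyond the scatter) as the step. No evidence at hand accounts for these steps.

Going by these compounds, a longer chain than hexyl remains open, so it is unknown whether the change seen at compound 3 continues. A chain carrying an amine or a carboxylic acid is equally untested in these compounds.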